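Trimethoxyphenyl series: acetyl-bearing core, aryl swap at the saturated carbon

The compounds below may be only part of what the source reports. "The series", "measured", "known", "first", "only" and "open" are said of these compounds alone.

Three compounds of this set have numbers in a functional assay on BGC-823 cells (Homo sapiens) for antiproliferative activity, read by MTT assay, tested at 1 uM; on this read-out higher numbers stand for a stronger effect at the one concentration tested and lower numbers for a weaker effect. Compound 1 `COc1ccc(C2OC(c3cc(OC)c(OC)c(OC)c3)=NN2C(C)=O)c(OC)c1` gives 6.3%. Compound 2 `COc1cc(C(=O)N/N=C/c2ccccc2C(F)(F)F)cc(OC)c1OC` gives 22.1%. Compound 3 `COc1cccc(/C=N/NC(=O)c2cc(OC)c(OC)c(OC)c2)c1OC` gives -0.1%. Of these, compound 1 stands second highest; its nearest neighbour is compound 3, whose number lies within the scatter of it, so no order between the two can be read, while compound 2 lies beyond the scatter and above compound 1. Within the data shown here, no pair of measured compounds differs in a single place, so no measured step is available for the change considered here.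

Compound 4 `COc1cc(C2=NN(C(C)=O)C(c3ccc(Cl)c(Cl)c3)O2)cc(OC)c1OC` is unmeasured. It differs from compound 1 in one place: 3,4-dichlorophenyl in place of 2,4-dimethoxyphenyl on a saturated ring carbon. Among the measured compounds shown here, nothing among the measured compounds isolates this change, so the expectation rests on the low numbers of compound 1 and compound 3 and the higher one of compound 2 alone. A small rise, not clearly beyond the scatter, is expected for the step of a number 4.7 percentage points higher from compound 1 to compound 4 (within the scatter). Compound 4 is estimated at 11%, in the range -6% to 30%.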

Compound 4, a percentage reported as inhibition, at one concentration (the size of the read-out at that concentration, not a potency): -0.8%
For compound 4 the middle estimate is 11.8 percentage points above the measured one, and the stated range covers the measured number.
By their numbers in this assay, from the lowest: compounds 4, 3 and 1 (each within the scatter of the next); then compound 2.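

On the saturated ring carbon of the shared core, 3,4-dichlorophenyl in place of 2,4-dimethoxyphenyl gives, in this assay, a number 7.1 percentage points lower from compound 1 to compound 4 (within the scatter). Among these compounds, this is the first single-place step, and it does not separate the two aryl groups at this position: exchanging the two methoxy groups for two chlorine atoms, with the ring kept, leaves no readable change at the one concentration tested. Nothing at hand accounts for this result.

Still open, going by these compounds, is whether an aryl group carrying an amine or a carboxylic acid on this carbon would move the number beyond the scatter. Also open, on these data alone, is whether a longer acyl chain in place of the acetyl group would change the read-out of compound 1 or compound 4, and whether the two aryl groups differ at other concentrations.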